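Replacing the carbamoyl side chain of compound 2

This account rests on a few compounds, and the source may have more. Where it says the series, first, only, none or still open, it means among the compounds named here.

Within the data shown here, in an ADME assay on microsomes from liver (Mus musculus) for metabolic stability, read by LC-MS, tested at 1 uM (a higher number here means faster removal of the compound, a lower number slower removal), compound 2 (`NC(=O)C1CCN(Cc2ccc([C@H]3CC[C@]4(CC3)OOC3(O4)C4CC5CC(C4)CC3C5)cc2)CC1`) gives 26 mL.min-1.g-1 as the only true number so far. Compound 1 (`NCCCOc1ccc([C@H]2CC[C@]3(CC2)OOC2(O3)C3CC4CC(C3)CC2C4)cc1`) gives < 7 mL.min-1.g-1 as a limit of the assay and not a number. Compound 3 (`c1cc([C@H]2CC[C@]3(CC2)OOC2(O3)C3CC4CC(C3)CC2C4)ccc1OCCC1CCNCC1`) is still unmeasured; its change from compound 2 is 2-(piperidin-4-yl)ethoxy in place of (4-carbamoylpiperidin-1-yl)methyl on an aromatic carbon and nothing else. Among the measured compounds shown here, the one measured step that bears on this is an at least 3.7-fold higher number from compound 1 to compound 2 (0.56 log units; beyond the scatter) with (4-carbamoylpiperidin-1-yl)methyl in place of 3-aminopropoxy. Compound 3 gives up that same (4-carbamoylpiperidin-1-yl)methyl group and again carries a chain joined through oxygen, so a move back along that step is expected in this assay towards slower removal. However, 2-(piperidin-4-yl)ethoxy is not 3-aminopropoxy, so the return is expected to be only partial. The expected step is a 2.2-fold lower number from compound 2 to compound 3 (0.34 log units; beyond the scatter) in that direction. For compound 3 the estimate is 12 mL.min-1.g-1 with an expected range from 6 mL.min-1.g-1 to 28 mL.min-1.g-1 for repeated measurements.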

Compound 3, intrinsic clearance in microsomes: 7 mL.min-1.g-1
Beside the measured number, compound 3's estimate is 1.7-fold (0.23 log units) above it, within the range that was stated.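

In this assay, 2-(piperidin-4-yl)ethoxy in place of (4-carbamoylpiperidin-1-yl)methyl gives a 3.7-fold lower number from compound 2 to compound 3 (0.57 log units; beyond the scatter). Slow removal is therefore not confined to the open 3-aminopropoxy chain of compound 1, since compound 3 shows it with a piperidine ring at the end of a chain joined through oxygen. Piperidin-4-yl in place of aminomethyl gives a number no lower from compound 1 to compound 3 (the limit leaves the size open). The size of this step cannot be read, because compound 1 gives only a limit of the assay and not a number: the limit of < 7 mL.min-1.g-1 in this assay, at which 1 of the 3 values shown sits.

On these data alone, compound 2 and compound 3 differ both in the link to the aromatic ring, carbon or oxygen, and in the carbamoyl group, so it stays open which of these goes with the change. A plain piperidin-1-ylmethyl group, without the carbamoyl, would help to separate the two.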